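The compounds below may be only part of what the source reports. "The series", "measured", "known", "first", "only" and "open" are said of these compounds alone.

In an ADME assay on NCM460 cells (Homo sapiens) for cytotoxicity, read by CCK-8 assay, with a stated time of 48 h (on this read-out lower numbers stand for stronger inhibition and higher numbers for weaker inhibition), compound 2 (`COc1ccc(/C=C\c2cc(OC)c(OC)c(OC)c2)cc1OCc1ccc(CN[C@H](C(=O)O)[C@H](C)O)cc1`) gives > 50000 nM, which is a limit of the assay and not a number. Compound 1 (`COc1ccc(/C=C\c2cc(OC)c(OC)c(OC)c2)cc1OCc1ccc(CN2CCCC[C@@H]2C(=O)O)cc1`) also gives only a limit, > 50000 nM. This leaves a step that the two limits leave unreadable from compound 1 to compound 2, so that step cannot guide a prediction. The evidence is thin: the limit of > 50000 nM in this assay, at which 2 of the 3 values shown sit. Compound 4 (`COc1ccc(/C=C\c2cc(OC)c(OC)c(OC)c2)cc1OCc1ccc(CNCCN(C)C)cc1`) differs from compound 2 as follows: 2-(dimethylamino)ethyl in place of 1-carboxy-2-hydroxypropyl on an amine nitrogen. This change removes the carboxy group. Compound 3 (`COc1ccc(/C=C\c2cc(OC)c(OC)c(OC)c2)cc1OCc1ccc(CN2CCCCC2C(=O)NCCNC(=O)OC(C)(C)C)cc1`), which also has no carboxy group, gives a true number, 28000 nM, so a measurable value is expected for compound 4 as well. The expected step, toward stronger inhibition, is an at least 2.7-fold lower number from compound 2 to compound 4 (0.44 log units; beyond the scatter). For compound 4 the estimated value is 18000 nM, with an expected range from 4000 nM to 50000 nM.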

Compound 4, half-maximal inhibitory concentration: 35000 nM
The estimate for compound 4 lay 1.9-fold (0.29 log units) below the measured number, within the range that was stated.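

Placing 2-(dimethylamino)ethyl on the amine nitrogen gives compound 4 a true number in this assay, a first reading for a compound with this amine. This yields an at least 1.4-fold lower number from compound 2 to compound 4 (0.15 log units; that floor lies within the scatter), and also an at least 1.4-fold lower number from compound 1 to compound 4 (0.15 log units; that floor lies within the scatter), while the step between compound 1 and compound 2 cannot be read. Both readable steps are only floors, so the full size of each remains unknown, because the starting value of each is a limit: the limit of > 50000 nM in this assay, at which 2 of the 4 values shown sit.

The compounds shown leave open whether losing the carboxy group or gaining the dimethylamino group matters more. An ethyl group on the same amine nitrogen would separate the two.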